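This account rests on a few compounds, and the source may have more. Where it says the series, first, only, none or still open, it means among the compounds named here.

Of the compounds shown here, three of a shared core have been measured in a functional assay on A-375 cells (Homo sapiens) for antiproliferative activity, read by MTT assay, with a stated time of 24 h, tested at 0.01 ug/mL; on this read-out lower numbers stand for a weaker effect and higher numbers for a stronger effect at the one concentration tested. Compound 1 `Cc1ccc2nc(C(=O)Nc3c(F)cc(-c4cccc(F)c4)cc3F)c(C)c(O)c2c1` gives 0.1%. Compound 2 `Cc1c(C(=O)Nc2ccc(-c3ccccc3)cc2)nc2ccccc2c1O` gives -0.11% in this assay. Compound 3 `Cc1ccc2nc(C(=O)Nc3c(F)cc(-c4cccc(F)c4)cc3F)c(C)c(C(=O)O)c2c1` gives -1.05% in this assay; this is the lowest of the three numbers, but its gaps to compound 2 and to compound 1 both lie within the usual scatter, so all three compounds sit at a negligible effect at the concentration tested. Going by the values given here, the one step between compounds that differ in a single place, a number 1.2 percentage points lower from compound 1 to compound 3 (within the scatter), is likewise within the scatter.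

Compound 4 `CCOc1ccc2nc(C(=O)Nc3c(F)cc(-c4cccc(F)c4)cc3F)c(C)c(C(=O)O)c2c1` has not yet been measured. It differs from compound 3 by ethoxy in place of methyl on an aromatic carbon. Among the compounds with values here, no measured step concerns an ethoxy replacing a methyl, so nothing bears directly on this change; the only step available, a number 1.2 percentage points lower from compound 1 to compound 3 (within the scatter), was within the scatter and concerned a different group. Compound 4 is therefore expected to show no step beyond the scatter in this assay, a number 0.6 percentage points higher from compound 3 to compound 4 (within the scatter). Compound 4 is estimated at -0.5%, with a range from -8% to 8%.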

Compound 4, a percentage reported as inhibition, at one concentration (the size of the read-out at that concentration, not a potency): 0.3%
Compound 4: middle estimate off by 0.8 percentage points, on the low side; the range from low to high includes it.
By their numbers in this assay, from the lowest: compounds 3, 2, 1 and 4 (each within the scatter of the next).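

In this assay, ethoxy in place of methyl on an aromatic carbon, at the place that is meta to a fused ring and para to a fused ring, gives a number 1.4 percentage points higher from compound 3 to compound 4 (within the scatter). Going by these compounds alone, this is the first measured step at this position, and it shows that a group of three heavy atoms with one hydrogen-bond acceptor can replace the methyl of one heavy atom without moving the number out of the scatter at the one concentration tested. No measurement at hand explains this result.

With all four numbers close to zero, the compounds shown leave open whether ethoxy differs from methyl at any concentration where an effect appears. They also leave open whether an amine, a longer alkoxy chain or a chlorine on this same carbon would give a step beyond the scatter.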